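Swapping chloro for methyl on a soluble quinazoline series

The source may report more compounds than this note shows. Statements on the series, on what has been measured and on what is new or still open speak of the compounds shown alone.

Compound 1 `CC(C)Nc1nc(NCc2ccco2)c2ccc(Cl)cc2n1` and compound 2 `CC(C)Nc1nc(NCc2ccco2)c2cc(Cl)ccc2n1` share the same atoms joined differently; how the two cores differ is not broken down here. In a physicochemical assay for solubility, at pH 2 (a lower number here means a less soluble compound, a higher number a more soluble compound), compound 1 gives only a limit, >= 30000 nM. In this assay compound 2 likewise gives only a limit, >= 30000 nM. Compound 3 `Cc1ccc2c(NCc3ccco3)nc(NC(C)C)nc2c1` differs from compound 1 by methyl in place of chloro on an aromatic carbon, and in this assay compound 3 also reaches only a limit, >= 30000 nM. The step that the two limits leave unreadable from compound 1 to compound 3 therefore cannot be read, since all three values sit at the limit of >= 30000 nM in this assay, at which 3 of the 3 values shown sit. Compound 4 `Cc1ccc2nc(NC(C)C)nc(NCc3ccco3)c2c1` differs from compound 2 by the same change, (methyl in place of chloro on an aromatic carbon). Because compound 2 sits at the limit of >= 30000 nM in this assay, at which 3 of the 3 values shown sit, the step from compound 2 to compound 4 is expected to be a step that the limit leaves unreadable from compound 2 to compound 4, most likely again unreadable. Compound 4 is expected to give about 40000 nM in this assay.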

Compound 4, solubility: >= 30000 nM
Compound 4: no number, only a limit (the forecaster's own chance of this, stated with the estimate: 85%); the middle value lies beyond the limit too.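

The step between compound 2 and compound 4 cannot be read, since both give only a limit: the limit of >= 30000 nM in this assay, at which 4 of the 4 values shown sit.

How soluble any of these compounds truly is, and whether chloro and methyl differ at all, stays open.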